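This account rests on a few compounds, and the source may have more. Where it says the series, first, only, none or still open, it means among the compounds named here.

Compound 1 `[O-][n+]1nc(NC2CCC2)[n+]([O-])c2ccc(F)cc21` is tested in an ADME assay on Vero cells (Chlorocebus sabaeus) for cytotoxicity, read by CellTiter-Glo, with a stated time of 72 h (on this read-out lower numbers stand for higher toxicity in this test and higher numbers for lower toxicity in this test), where compound 1 gives 1.6 ug/mL. Compound 2 `[O-][n+]1nc(NC2CCCCC2)[n+]([O-])c2ccc(F)cc21` differs from compound 1 by cyclohexyl in place of cyclobutyl on a nitrogen on an aromatic ring. For compound 2 the result in this assay is the limit < 2.5 ug/mL, not a number. Compound 3 `[O-][n+]1nc(NC2CCC2)[n+]([O-])c2ccc(Cl)cc21` differs from compound 1 by chloro in place of fluoro on an aromatic carbon, and in this assay compound 3 gives 1.6 ug/mL.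

The step that the limit leaves unreadable from compound 1 to compound 2 cannot be sized, since the value of compound 2 is only the limit (the limit of < 2.5 ug/mL in this assay, at which 1 of the 3 values shown sits). The step of no change at the digits printed from compound 1 to compound 3 (within the scatter) shows that swapping the halogen left the read-out where it was, within the scatter.

Compound 4 `[O-][n+]1nc(NC2CCCCC2)[n+]([O-])c2ccc(Cl)cc21` has not yet been measured. It differs from compound 3 by cyclohexyl in place of cyclobutyl on a nitrogen on an aromatic ring, the same change as that from compound 1 to compound 2, at the same place. With only a limit for compound 2 and no change along no change at the digits printed from compound 1 to compound 3 (within the scatter), the expected step is a 1.1-fold lower number from compound 3 to compound 4 (0.03 log units; within the scatter), a small one. On that basis compound 4 is expected to give about 1.5 ug/mL in this assay, somewhere between 0.7 ug/mL and 3 ug/mL.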

Compound 4, half-maximal cytotoxic concentration: 2.6 ug/mL
Compound 4: the middle estimate sits 1.7-fold (0.24 log units) below what was measured; measured number inside the range.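

The result for compound 2 in this assay is a limit, not a number. Chloro in place of fluoro can now be followed on two cores, with an at least 1.0-fold higher number from compound 2 to compound 4 (0.01 log units; that floor lies within the scatter) on the cyclohexyl core, and the comparison reads: the same change on two cores in this assay, no change at the digits printed (within the scatter) from compound 1 to compound 3 and an at least 1.0-fold higher number (0.01 log units; that floor lies within the scatter) from compound 2 to compound 4; the limit leaves it open whether they differ. So the compounds shown neither establish that this swap carries over unchanged from one core to the other nor show that it behaves differently; cyclohexyl in place of cyclobutyl gives a 1.6-fold higher number from compound 3 to compound 4 (0.21 log units; within the scatter) among the chloro compounds, and its partner step among the fluoro compounds cannot be read.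

The compounds shown hold only fluoro or chloro on the aromatic carbon, and only cyclobutyl or cyclohexyl on the nitrogen. As far as these compounds go, what a longer open chain or an amine on that nitrogen, or a methoxy group or a nitrile in place of the halogen, would do in this assay stays open.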